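This account rests on a few compounds, and the source may have more. Where it says the series, first, only, none or still open, it means among the compounds named here.

Compound 2 `COc1ccc2c(=O)c(/C=C/C(=O)Nc3cc(C)ccc3C)coc2c1` carries a 2,5-dimethylphenyl group on its amide-type nitrogen, and in a functional assay (QGY7701 cells, Homo sapiens) for inhibition, read by MTT assay, with a stated time of 48 h (on this read-out higher numbers stand for weaker inhibition and lower numbers for stronger inhibition), compound 2 gives only a limit of > 100000 nM, not a number. Among the compounds with values here, the single measured step shows where this leaves it: compound 1 `COc1ccc2c(=O)c(/C=C/C(=O)NCc3cccc(F)c3)coc2c1`, with 3-fluorobenzyl in that place, gives 28600 nM in this assay, and the change to 2,5-dimethylphenyl produced an at least 3.4-fold higher number from compound 1 to compound 2 (0.54 log units; beyond the scatter). The full size of that loss for compound 2 is not known because of the limit of > 100000 nM in this assay, at which 1 of the 2 values shown sits.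

Compound 3 `COc1ccc2c(=O)c(/C=C/C(=O)Nc3ccc(Cl)cc3)coc2c1` differs from compound 2 in one place: 4-chlorophenyl in place of 2,5-dimethylphenyl on an amide-type nitrogen. Within the data shown here, no measured step compares one aryl group with another on this nitrogen; the only step measured, from a benzyl to an aryl amide, does not speak to an exchange of substituents within the aryl series. The expectation for compound 3 is therefore anchored near compound 2, with wide uncertainty and a real chance that this assay again reports a limit. Compound 3 is estimated to give 90000 nM in this assay, within 30000 nM to 250000 nM, a step of an at least 1.1-fold lower number from compound 2 to compound 3 (0.04 log units; that floor lies within the scatter).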

Compound 3, half-maximal inhibitory concentration: > 100000 nM
Compound 3 ended at the assay's limit (the forecaster's own chance of this, stated with the estimate: 50%); middle value at least 1.1-fold (0.04 log units) away from the limit.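

The exchange of 3-fluorobenzyl for 4-chlorophenyl on the amide-type nitrogen gave an at least 3.4-fold higher number from compound 1 to compound 3 (0.54 log units; beyond the scatter) in this assay, so the loss seen with 2,5-dimethylphenyl is not tied to that one aryl group. Among the three compounds shown, both aryl amides now lie on the weak side of the benzyl amide, and none goes against this, although the comparison rests on limits and not on numbers. The step from compound 2 to compound 3 cannot be read, and nothing can be said about how the two aryl groups rank, because both compounds stand at the same limit: the limit of > 100000 nM in this assay, at which 2 of the 3 values shown sit.

From the compounds shown here alone, what remains open is whether the better value of compound 1 belongs to the benzyl link or to its fluorine, a question that a 3-fluorophenyl or a 4-chlorobenzyl group on this nitrogen would bear on directly. Going by these compounds, it is also open how a longer chain such as phenethyl, or an aryl ring carrying an amine or a carboxylic acid, would read in this assay.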